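The compounds below may be only part of what the source reports. "The series", "measured", "known", "first", "only" and "open" are said of these compounds alone.

Measured so far:
- compound 1 `O=C1c2[nH]nc(NS(=O)(=O)c3ccc4ccccc4c3)c2CCN1CC1CCNCC1`, 310 nM
- compound 2 `CC(C)Cc1cc(CNS(=O)(=O)c2ccc(C(C)(C)C)cc2)nn1-c1ccccc1`, 8780 nM
- compound 3 `CC(C)Cc1cc(CNS(=O)(=O)Cc2cccc3ccccc23)nn1-c1ccc(F)cc1`, "not determined" (no result reported)

In a functional assay on HeLa cells for antagonist activity at 5-hydroxytryptamine receptor 6 (Homo sapiens), read by HTRF and cAMP accumulation, with stated times of 10 min and 30 min (a lower number here means a stronger inhibitor, a higher number a weaker inhibitor), compound 2 gives 8780 nM, the highest of the two numbers available; its nearest neighbour, compound 1, gives 310 nM, a gap beyond the usual scatter. Compound 3 has no number in this assay.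

Compound 4 `CC(C)Cc1cc(CNS(=O)(=O)c2c(Cl)cccc2Cl)nn1-c1ccccc1` differs from compound 2 in one place: 2,6-dichlorophenyl in place of 4-(tert-butyl)phenyl on a sulfonyl sulfur. For the measured compounds named here, no measured pair shows the effect of such a change, so the direction is open. The expectation is a step from compound 2 to compound 4 of a 1.3-fold lower number from compound 2 to compound 4 (0.10 log units; within the scatter), that is, no change clearly beyond the scatter. The estimate for compound 4 in this assay is 7000 nM, with a range of 2000 nM to 25000 nM.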

Compound 4, half-maximal inhibitory concentration: 5650 nM
Compound 4: the middle estimate sits 1.2-fold (0.09 log units) above what was measured; low and high end bracket the measured number.
By their numbers in this assay, from the lowest: compound 1; then compounds 4 and 2 (each within the scatter of the next).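

For the compounds shown here, the first matched pair at this position, on a sulfonyl sulfur whose other neighbour is the sulfonamide nitrogen, gives in this assay a 1.6-fold lower number from compound 2 to compound 4 (0.19 log units; within the scatter) for 2,6-dichlorophenyl in place of 4-(tert-butyl)phenyl. The two aryl groups, different in their substituents and in where those substituents sit, are therefore not told apart by this read-out. No evidence on hand bears on this result.

Still open, from the compounds shown here alone, is whether a single chlorine reads the same as the two in compound 4. Also open, going by these compounds, is how an amine or a carboxylic acid on this phenyl ring would read.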